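Swapping ethoxy for phenyl on a saturated ring carbon

The source may report more compounds than this note shows. Statements on the series, on what has been measured and on what is new or still open speak of the compounds shown alone.

Compound 1 (`O=c1c([C@@H]2C[C@H](c3ccccc3)ON2c2ccccc2)coc2ccc(Br)cc12`) gives 60000 nM in a functional assay on THP-1 cells (Homo sapiens) for inhibition, read by sulforhodamine B assay, with a stated time of 48 h (on this read-out lower numbers stand for stronger inhibition and higher numbers for weaker inhibition), as its measured result. Compound 2 (`CCO[C@H]1C[C@@H](c2coc3ccc(C)cc3c2=O)N(c2ccccc2)O1`) gives 41000 nM there, so the two stand together within the usual scatter. Compound 3 (`Cc1ccc2occ([C@@H]3C[C@H](c4ccccc4)ON3c3ccccc3)c(=O)c2c1`) has phenyl in place of ethoxy on a saturated ring carbon. Within the data shown here, no measured step shows what this change does, so the expectation leans only on compound 2 at 41000 nM and compound 1 at 60000 nM as neighbours. The expected change is small, a 1.1-fold higher number from compound 2 to compound 3 (0.04 log units; within the scatter) in this assay and not beyond the scatter. Compound 3 is estimated at 45000 nM with 18000 nM to 100000 nM as its expected range.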

Compound 3, half-maximal inhibitory concentration: > 60000 nM
Compound 3: no number, only a limit (the forecaster's own chance of this, stated with the estimate: 15%); at least 1.3-fold (0.12 log units) between middle value and limit.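

In this assay compound 3 gives only a limit, > 60000 nM, and not a number. Phenyl in place of ethoxy on this saturated ring carbon gives an at least 1.4-fold higher number from compound 2 to compound 3 (0.16 log units; that floor lies within the scatter), so the change brings no gain here, while the true size of the step stays unknown. Methyl in place of bromo on an aromatic carbon gives a number no lower from compound 1 to compound 3 (the limit leaves the size open) and the size of this step cannot be read: the limit of > 60000 nM in this assay, at which 1 of the 3 values shown sits.

Going by these compounds, what an amine or a carboxylic acid on this ring carbon would give in this assay stays open.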